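Chain change from compound 3 to compound 4: expected cytotoxicity

The compounds below may be only part of what the source reports. "The series", "measured", "known", "first", "only" and "open" are said of these compounds alone.

- compound 1 (`CCCCCCCc1cc2cn([C@H]3C[C@H](O)[C@@H](CO)O3)c(=O)nc2o1`) gives (> 50000 nM)
- compound 2 (`CCCCCCCCCCc1cc2cn([C@H]3C[C@H](O)[C@@H](CO)O3)c(=O)nc2o1`) gives (> 50000 nM)
- compound 3 (`C=CCCCc1cc2cn([C@H]3C[C@H](O)[C@@H](CO)O3)c(=O)nc2o1`) gives (> 200000 nM)

In a functional assay on HEL cells (Homo sapiens) for cytotoxicity (on this read-out lower numbers stand for higher toxicity in this test and higher numbers for lower toxicity in this test), compound 3 stands at a limit (> 200000 nM) and not at a number. The entries for compound 1 and compound 2 are limits too. Compound 4 (`C#CCCCCCc1cc2cn([C@H]3C[C@H](O)[C@@H](CO)O3)c(=O)nc2o1`) carries but-3-yn-1-yl in place of vinyl on a saturated chain carbon, three bonds along the chain from an aromatic carbon. The chain changes that bear on this are (a step that the two limits leave unreadable from compound 1 to compound 3) and (a step that the two limits leave unreadable from compound 2 to compound 3), along with (a step that the two limits leave unreadable from compound 1 to compound 2), and none of them has a readable size. The expectation for (an at least 1.6-fold lower number from compound 3 to compound 4 (0.22 log units; that floor lies within the scatter)) is therefore no change beyond the scatter, in either direction. Compound 4 is estimated at (120000 nM) with an expected range from 40000 nM to (300000 nM).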

Compound 4, half-maximal cytotoxic concentration: > 200000 nM
Compound 4 gave a limit, no number; the forecaster's own chance of this, stated with the estimate: 85%; at least 1.6-fold (0.22 log units) between middle value and limit.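

In this assay, among the compounds shown here, compound 4 gives > 200000 nM, a limit, and no step linking it to compound 1, compound 2 or compound 3 can be read. The compounds shown leave open whether any of these chain changes shifts the read-out in this assay.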